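This account rests on a few compounds, and the source may have more. Where it says the series, first, only, none or still open, it means among the compounds named here.

Two members of a series built on a shared sulfonylurea-type core have been measured in a functional assay on the whole organism (blood, strain albino) with Mus musculus as the target, with stated times of 6 days and 4 h, at a dose of 0.4 mmol/kg by the oral route; a higher number here means more inhibition at the dose given (going by the name of the read-out), a lower number less inhibition. Compound 1, `C=CCNC(=S)NS(=O)(=O)c1ccc(-n2nc(C(=O)O)cc2C)cc1`, gives -6% in this assay. Compound 2, `CCCCNC(=O)NS(=O)(=O)c1ccc(-n2nc(C)cc2C)cc1`, gives 2% in this assay. Of the two numbers that of compound 2 is the one that stands higher, yet the gap between compound 2 and compound 1 lies within the usual scatter of this kind of measurement, so the two compounds cannot be told apart on this evidence, and both sit close to no inhibition at the dose used.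

The next compound, compound 3, `C=CCNC(=S)NS(=O)(=O)c1ccc(-n2nc(C)cc2C)cc1`, has not yet been measured. It differs from compound 2 in one place: a group of 6 heavy atoms (4 carbon, 1 nitrogen, 1 sulfur; no ring) in place of a group of 7 heavy atoms (5 carbon, 1 nitrogen, 1 oxygen; no ring), on a sulfonamide nitrogen. For the measured compounds named here, no measured pair shows the effect of this kind of change, so nothing beyond the two values above can guide the expectation. Compound 3 also shares its sulfonamide substituent with compound 1, whose own number is -6%.

Given that compound 2 and compound 1 both show essentially no inhibition, the step of a number 2 percentage points lower from compound 2 to compound 3 (within the scatter) is expected to be no larger than the scatter. Compound 3 is therefore estimated to give 0% in this assay, with a likely range from -15% to 15%.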

Compound 3, a percentage reported as inhibition, in the whole organism at one dose (the size of the read-out at that dose, not a potency): -1%
Compound 3: middle estimate off by 1 percentage points, on the high side; the range from low to high includes it.
By their numbers in this assay, from the lowest: compounds 1, 3 and 2 (each within the scatter of the next).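

Exchanging butylcarbamoyl on the sulfonamide nitrogen for the sulfur-bearing group of 6 heavy atoms gives a number 3 percentage points lower from compound 2 to compound 3 (within the scatter) in this assay and so shows no effect that can be separated from the noise of the measurement, even though a carbonyl gives way to its sulfur counterpart and the chain changes too. For the compounds shown here, the compounds also offer a first reading at a second place: methyl in place of carboxy on an aromatic carbon gives a number 5 percentage points higher from compound 1 to compound 3 (within the scatter) and so likewise leaves the compounds indistinguishable, all of them lying close to no inhibition at this dose. No further information is available that could account for these results.

With every number this close to no inhibition, the compounds leave open whether either place can influence the read-out at all, at this dose or at any other. Also unanswered is how a longer chain than butyl on the sulfonamide nitrogen, or an amine or a chlorine in place of methyl on the aromatic carbon, would read in this assay on the shared core.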